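A few compounds are considered here, and "the series" means these few. Any claim that something is new, unique, unknown or untested is made for them only; others in the source may bear on it.

Compound 1 `CCn1c(C(=O)NCC(=O)OC)ccc1C(CC)(CC)c1ccc(OCS(=O)(=O)c2ccccc2)c(C)c1`, compound 2 `CCn1c(C(=O)N[C@H](C)C(=O)OC)ccc1C(CC)(CC)c1ccc(OCS(=O)(=O)c2ccccc2)c(C)c1`, compound 3 `CCn1c(C(=O)NCCO)ccc1C(CC)(CC)c1ccc(OCS(=O)(=O)c2ccccc2)c(C)c1` and compound 4 `CCn1c(C(=O)N[C@H](C)CO)ccc1C(CC)(CC)c1ccc(OCS(=O)(=O)c2ccccc2)c(C)c1` belong to one series. In a functional assay on MCF7 cells (Homo sapiens) for antiproliferative activity, read by MTT assay, with a stated time of 24 h (on this read-out higher numbers stand for weaker inhibition and lower numbers for stronger inhibition), compound 1 gives only a limit, > 50000 nM. In this assay compound 2 likewise gives only a limit, > 50000 nM. The change between them, (methyl in place of hydrogen on a saturated chain carbon bound to an amide-type nitrogen and a carbonyl carbon), thus made a step that the two limits leave unreadable from compound 1 to compound 2. Going from compound 1 to compound 3 the core changes by hydroxymethyl in place of methoxycarbonyl on a saturated chain carbon bound to an amide-type nitrogen, and in this assay compound 3 gives 15500 nM, which is an at least 3.2-fold lower number from compound 1 to compound 3 (0.50 log units; beyond the scatter). Compound 4 carries the same kind of change as compound 2, (methyl in place of hydrogen on a saturated chain carbon bound to an amide-type nitrogen and a saturated chain carbon), though here the carbon is bound to an amide-type nitrogen and a saturated chain carbon rather than to an amide-type nitrogen and a carbonyl carbon. Because a step that the two limits leave unreadable from compound 1 to compound 2 gives no readable size, compound 4 is expected to move little, an estimated step of a 1.0-fold lower number from compound 3 to compound 4 (0.01 log units; within the scatter). Compound 4 is estimated at 15000 nM, between 6000 nM and 40000 nM.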

Compound 4, half-maximal inhibitory concentration: 10600 nM
Beside the measured number, compound 4's estimate is 1.4-fold (0.15 log units) above it; low and high end bracket the measured number.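

In this assay, methyl in place of hydrogen gives a 1.5-fold lower number from compound 3 to compound 4 (0.17 log units; within the scatter), while the same methyl on the ester pair cannot be read, since both of its values are limits: the limit of > 50000 nM in this assay, at which 2 of the 4 values shown sit. Hydroxymethyl in place of methoxycarbonyl lowers the number on both cores, with an at least 4.7-fold lower number from compound 2 to compound 4 (0.67 log units; beyond the scatter), and the change that also adds the methyl gives an at least 4.7-fold lower number from compound 1 to compound 4 (0.67 log units; beyond the scatter). So the direction of this change carries from one core to the other, but its size may or may not carry: the same change on two cores in this assay, an at least 3.2-fold lower number (0.50 log units; beyond the scatter) from compound 1 to compound 3 and an at least 4.7-fold lower number (0.67 log units; beyond the scatter) from compound 2 to compound 4; the limit leaves it open whether they differ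

The compounds shown leave open how a carboxylic acid or an amine in place of the hydroxymethyl would read. They also leave open what a longer chain on the amide nitrogen would do.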